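From Methylcarbamoyl to Carboxypyridinyl on the Shared Core

The source may hold more compounds than are shown below. What is called first, only, known or untested is meant among the compounds shown, and "the series" means these compounds.

Compound 1, `COC(=O)c1cnc(C(=O)CCc2ccc(COc3ccccc3)cc2)o1`, gives 1.6 nM in an assay for inhibition of Fatty-acid amide hydrolase 1 (Rattus norvegicus); a lower number here means a stronger inhibitor, a higher number a weaker inhibitor. Compound 2, `N#Cc1cccc(-c2cnc(C(=O)CCc3ccc(COc4ccccc4)cc3)o2)n1`, gives 0.56 nM. Compound 3, `CNC(=O)c1cnc(C(=O)CCc2ccc(COc3ccccc3)cc2)o1`, gives 3.6 nM.

Compound 3 holds the highest number of the three, as the steps of a 2.3-fold higher number from compound 1 to compound 3 (0.35 log units; beyond the scatter) and a 6.4-fold higher number from compound 2 to compound 3 (0.81 log units; beyond the scatter) show. Compound 4, `O=C(O)c1ccc(-c2cnc(C(=O)CCc3ccc(COc4ccccc4)cc3)o2)nc1`, differs from compound 3 by 5-carboxypyridin-2-yl in place of methylcarbamoyl on an aromatic carbon. The step that bears on this change is a 6.4-fold higher number from compound 2 to compound 3 (0.81 log units; beyond the scatter), read in reverse: a pyridinyl group in place of methylcarbamoyl went with a lower number. Among the compounds with values here, no measured step covers a carboxy group in place of a nitrile on that pyridine, so the expectation is less firm. A lower number is nonetheless expected for compound 4, a 2.4-fold lower number from compound 3 to compound 4 (0.38 log units; beyond the scatter), with an estimate of 1.5 nM, between 0.3 nM and 8 nM.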

Compound 4, inhibition constant: 4.6 nM
Compound 4: middle estimate off by 3.1-fold (0.49 log units), on the low side; low and high end bracket the measured number.
By their numbers in this assay, from the lowest: compound 2; then compound 1; then compounds 3 and 4 (each within the scatter of the next).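

In this assay, replacing methylcarbamoyl with 5-carboxypyridin-2-yl on this aromatic carbon gives no change beyond the scatter (a 1.3-fold higher number from compound 3 to compound 4 (0.11 log units; within the scatter)). A pyridine at this position therefore does not by itself bring the low number of compound 2, as the steps to compound 4 show (an 8.2-fold higher number from compound 2 to compound 4 (0.91 log units; beyond the scatter); a 2.9-fold higher number from compound 1 to compound 4 (0.46 log units; beyond the scatter)). Nothing available explains these steps.

Compound 2 and compound 4 differ in both the pyridine substituent and where it sits, so the effects of these two features remain unseparated. Also open, on these data alone, is how a pyridine bearing an amine would read here.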